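Swapping a dichlorophenyl for a fluorophenyl on the styryl arm

The source may hold more compounds than are shown below. What is called first, only, known or untested is meant among the compounds shown, and "the series" means these compounds.

Of the compounds shown here, three sharing one core have been measured in an assay on isolated protein with Bile acid receptor (Homo sapiens) as the target; a lower number here means that less compound is needed, a higher number that more compound is needed for the effect. Compound 1 `COC(=O)/C=C/c1cccc(N(Cc2ccc(/C=C/c3c(Cl)cccc3Cl)cc2)C(=O)C(C)C)c1` gives 195 nM, the second highest of the three numbers. Compound 3 `COC(=O)/C=C/c1cccc(N(Cc2ccc(/C=C/c3c(C)cc(C)cc3C)cc2)C(=O)NC(C)C)c1` gives 431 nM, and compound 2 `COC(=O)/C=C/c1cccc(N(Cc2ccc(/C=C/c3ccccc3F)cc2)C(=O)C2CCCCC2)c1` gives 64 nM; both differ from compound 1 in more than one place, so no single step can be read from them. Compound 4 `COC(=O)/C=C/c1cccc(N(Cc2ccc(/C=C/c3ccc(F)cc3)cc2)C(=O)C(C)C)c1` differs from compound 1 in one place: 4-fluorophenyl in place of 2,6-dichlorophenyl on a double-bonded chain carbon bound to a double-bonded chain carbon. Nothing measured isolates this change. Because compound 2 gives 64 nM with a fluorophenyl of its own, a modest lowering of the number for compound 4 is expected, as a 1.3-fold lower number from compound 1 to compound 4 (0.11 log units; within the scatter). Compound 4 is therefore estimated at 150 nM, within 50 nM to 450 nM.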

Compound 4, half-maximal effective concentration: 120 nM
Compound 4: middle estimate off by 1.3-fold (0.10 log units), on the high side, within the range that was stated.
By their numbers in this assay, from the lowest: compounds 2, 4 and 1 (each within the scatter of the next, the first and the last beyond it); then compound 3.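

In this assay, putting 4-fluorophenyl in place of 2,6-dichlorophenyl gives a 1.6-fold lower number from compound 1 to compound 4 (0.21 log units; within the scatter) and so the two compounds cannot be told apart. With the rest of compound 1 unchanged, this position therefore tolerates a ring with one fluorine as well as a ring with two chlorines. No measured evidence offers an explanation for this result.

The swap changes both the halogen and its place on the ring, so the effect of each remains unresolved. Also open, as far as these compounds go, is whether a larger group here, such as 4-methoxyphenyl, or a pyridine ring would move the number beyond the scatter.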